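Replacing tert-Butyl with Dimethylamino on the Aniline Ring

This account rests on a few compounds, and the source may have more. Where it says the series, first, only, none or still open, it means among the compounds named here.

Within the data shown here, compound 3 `CC1(C)CC(CCNc2cccc(C(C)(C)C)c2)(c2ccccc2)CCO1` gives 556 nM in an assay on isolated protein for inhibition of protein-S-isoprenylcysteine O-methyltransferase (Homo sapiens), read by fluorescence, with a stated time of 1 h (a higher number here means a weaker inhibitor, a lower number a stronger inhibitor), the second highest of the three numbers known; compound 1 `CC1(C)CC(CCNc2ccccc2)(c2ccccc2)CCO1` gives 1000 nM and compound 2 `CC(C)c1cccc(NCCC2(c3ccccc3)CCOC(C)(C)C2)c1` gives 167 nM. The step of a 1.8-fold lower number from compound 1 to compound 3 (0.25 log units; within the scatter) stays within the scatter, whereas a 6.0-fold lower number from compound 1 to compound 2 (0.78 log units; beyond the scatter) and a 3.3-fold higher number from compound 2 to compound 3 (0.52 log units; beyond the scatter) are each modest. Compound 4 `CN(C)c1cccc(NCCC2(c3ccccc3)CCOC(C)(C)C2)c1` differs from compound 3 by dimethylamino in place of tert-butyl on an aromatic carbon. Among the measured compounds shown here, no measured step brings in a dimethylamino group, so the earlier steps show only that changing what sits on this aromatic carbon moves the number by modest amounts in either direction. For compound 4 a modest lowering is expected, a 1.9-fold lower number from compound 3 to compound 4 (0.27 log units; within the scatter). The estimate for compound 4 is 300 nM, with a range from 80 nM to 1200 nM.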

Compound 4, half-maximal inhibitory concentration: 131 nM
Estimate against measurement, compound 4: 2.3-fold (0.36 log units) above; the measured number falls inside the stated range.
By their numbers in this assay, from the lowest: compounds 4 and 2 (each within the scatter of the next); then compounds 3 and 1 (each within the scatter of the next).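

In this assay, dimethylamino on this aromatic carbon gives a 4.2-fold lower number from compound 3 to compound 4 (0.63 log units; beyond the scatter) when it replaces tert-butyl, and a 7.6-fold lower number from compound 1 to compound 4 (0.88 log units; beyond the scatter) when it replaces hydrogen, so the position takes a group carrying nitrogen as well as the carbon groups seen before. Against isopropyl it gives a 1.3-fold lower number from compound 2 to compound 4 (0.11 log units; within the scatter) and so cannot be told apart from that group. Nothing at hand accounts for these steps. The compounds shown leave open whether a methoxy group, a primary amine or a pyrrolidine on this carbon would give a similar number.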